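This account rests on a few compounds, and the source may have more. Where it says the series, first, only, none or still open, it means among the compounds named here.

Working notes on the series. In an assay on HEK293 cells for inhibition of Voltage-dependent T-type calcium channel subunit alpha-1G (Homo sapiens), read by fluorescence, tested at 10 uM (a lower number here means less inhibition, a higher number more inhibition at the concentration tested (going by the name of the read-out)), compound 1 `CCCc1nc(-c2ccccc2)c(CNCCCN2CCN(c3ccccc3)CC2)o1` gives 43.7%, the lowest of the three numbers to hand; compound 3 `CCCc1nc(-c2ccccc2)c(CNCCN2CCN(c3ccccc3F)CC2)o1` gives 46.5%, within the scatter of compound 1, while compound 2 `CCCc1nc(-c2ccccc2)c(CNCCN2CCN(c3cccc(C)c3C)CC2)o1` gives 66.7%, beyond the scatter above it. Among the measured compounds shown here, the one measured step on the aryl of the piperazine, a number 20.2 percentage points lower from compound 2 to compound 3 (beyond the scatter), is the only step that bears on the next compound. Compound 4 `CCCc1nc(-c2ccccc2)c(CNCCCN2CCN(c3ccccc3C)CC2)o1` differs from compound 1 by methyl in place of hydrogen on an aromatic carbon. Since the methylated aryl of compound 2 sits well above the fluorinated aryl of compound 3 in this assay, an upward step of modest size is expected, a number 11.3 percentage points higher from compound 1 to compound 4 (beyond the scatter), with compound 4 estimated at 55% (range 38% to 72%).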

Compound 4, a percentage reported as inhibition, at one concentration (the size of the read-out at that concentration, not a potency): 54.5%
The estimate for compound 4 lay 0.5 percentage points above the measured number; the measured number falls inside the stated range.
By their numbers in this assay, from the lowest: compounds 1, 3 and 4 (each within the scatter of the next, the first and the last beyond it); then compound 2.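

In this assay, among the compounds shown here, the change from phenyl to 2-methylphenyl gives a number 10.8 percentage points higher from compound 1 to compound 4 (beyond the scatter) and is the first step to isolate a single methyl on the aryl, here on an aromatic carbon ortho to a large group. It shows that this one added carbon is enough to move the number beyond the scatter. Nothing at hand accounts for the step.

Still open, on these data alone, is whether an ethyl, a methoxy or a chlorine on the same aromatic carbon moves the number in the same direction and by a similar amount.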